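The source may report more compounds than this note shows. Statements on the series, on what has been measured and on what is new or still open speak of the compounds shown alone.

Within the data shown here, the three compounds measured so far share one core and differ only in the group on the aromatic carbon that carries fluoro in compound 1 `COc1ccc(/C=C2\c3cc(OC)c(OC)c(OC)c3CC[C@@H]2O)cc1F`. In a functional assay on SK-OV-3 cells (Homo sapiens) for inhibition, read by MTT assay (on this read-out higher numbers stand for weaker inhibition and lower numbers for stronger inhibition), compound 1 gives 1 nM. Compound 2 `COc1ccc(/C=C2\c3cc(OC)c(OC)c(OC)c3CC[C@@H]2O)cc1N`, with amino there, gives 740 nM, and compound 3 `COc1ccc(/C=C2\c3cc(OC)c(OC)c(OC)c3CC[C@@H]2O)cc1C(N)=O`, with carbamoyl, gives 1440 nM. Compound 3 thus has the highest number of the three; its nearest neighbour is compound 2, a 1.9-fold higher number from compound 2 to compound 3 (0.29 log units; within the scatter), while the larger gap is a 1400-fold higher number from compound 1 to compound 3 (3.16 log units; beyond the scatter).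

Compound 4 `COc1ccc(/C=C2\c3cc(OC)c(OC)c(OC)c3CC[C@@H]2O)cc1C` differs from compound 3 by methyl in place of carbamoyl on an aromatic carbon. All three measured steps bear on this position. The two large ones, a 740-fold higher number from compound 1 to compound 2 (2.87 log units; beyond the scatter) and a 1400-fold higher number from compound 1 to compound 3 (3.16 log units; beyond the scatter), show that replacing the single-atom fluoro with either larger group raised the number enormously, whereas the step of a 1.9-fold higher number from compound 2 to compound 3 (0.29 log units; within the scatter) between the two larger groups stayed within the scatter. Methyl, like fluoro, is a single heavy atom without donors or acceptors, so a large step back toward compound 1 is expected: a 140-fold lower number from compound 3 to compound 4 (2.16 log units; beyond the scatter). Compound 4 is therefore estimated at 10 nM, with a range from 1.5 nM to 80 nM, the uncertainty reflecting that no single-atom group other than fluoro has been measured here.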

Compound 4, half-maximal inhibitory concentration: 730 nM
Compound 4: the middle estimate sits 73-fold (1.86 log units) below what was measured; the whole stated range lies below it.
By their numbers in this assay, from the lowest: compound 1; then compounds 4, 2 and 3 (each within the scatter of the next).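

In this assay, methyl does not behave like fluoro at this position, ortho to a methoxy group: a 730-fold higher number from compound 1 to compound 4 (2.86 log units; beyond the scatter), so a group of 1 heavy atom does not by that fact alone keep the number of compound 1. Methyl instead joins the two larger groups, with a 2.0-fold lower number from compound 3 to compound 4 (0.30 log units; within the scatter) and a 1.0-fold lower number from compound 2 to compound 4 (0.01 log units; within the scatter); taking away the hydrogen-bond donor and acceptor of carbamoyl thus leaves no change that can be read, and these three compounds cannot be told apart here. Among the four groups, only fluoro stands apart from the rest, and nothing measured on these compounds says why.

From the compounds shown here alone, what remains open is whether fluoro is alone in this or whether other groups on this aromatic carbon, such as chloro, hydroxy or plain hydrogen, would give numbers close to that of compound 1. Going by these compounds, it is also open where a nitrile, a trifluoromethyl group or a carboxylic acid would fall, and whether any of them would leave the level shared by compounds 2, 3 and 4.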